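A few compounds are considered here, and "the series" means these few. Any claim that something is new, unique, unknown or untested is made for them only; others in the source may bear on it.

Measured in a functional assay on K562 cells (Homo sapiens) for inhibition; a higher number here means a weaker inhibitor, a lower number a stronger inhibitor:
compound 1 `C[C@@]1(n2cnc3c(N)ncnc32)O[C@H](CO)[C@@H](O)[C@H]1O`: 53000 nM
compound 2 `CNc1ncnc2c1ncn2C1O[C@H](CO)[C@@H](O)[C@@]1(C)O`: > 100000 nM

Compound 2 reads > 100000 nM, and this is a limit of this assay, not a number. For the measured compounds named here, compound 1 gives 53000 nM, the only true number available so far.

The next compound, compound 3 `C[C@]1(O)C(n2cnc3c(NC4CC4)ncnc32)O[C@H](CO)[C@H]1O`, changes compound 2 in one place: cyclopropyl in place of methyl on a nitrogen on an aromatic ring. In words, cyclopropyl stands in place of methyl on a nitrogen on an aromatic ring, so methylamino becomes cyclopropylamino.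

Going by the values given here, no measured pair in this small set isolates such a change, so the data do not show what it does in this assay. The expectation therefore rests on compound 2, with its reading of > 100000 nM, and it is that compound 3 will stay in the same region, with no change beyond the scatter. The expected step is a number no higher from compound 2 to compound 3 (the limit leaves the size open). For compound 3 the estimated value is 100000 nM, with an expected range from 40000 nM to 250000 nM. A report of only a limit would come as no surprise.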

Compound 3, half-maximal inhibitory concentration: > 100000 nM
Compound 3 was reported as a limit (the forecaster's own chance of this, stated with the estimate: 60%); the middle value lies on the limit itself.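

Compound 3, like compound 2, is reported in this assay only as a limit and not as a number, so no step can be read between compound 2 and compound 3 because both stand at the same limit: the limit of > 100000 nM in this assay, at which 2 of the 3 values shown sit. The compounds shown leave open what cyclopropyl in place of methyl on a nitrogen on an aromatic ring does in this assay.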